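Turning the ring stereochemistry of a weak antagonist

The compounds below may be only part of what the source reports. "The series", "measured", "known", "first", "only" and "open" are said of these compounds alone.

Of the compounds shown here, two have been measured in an assay on HEK293 cells for antagonist activity at transient receptor potential cation channel subfamily V member 3 (Homo sapiens), read by FLIPR and calcium flux; a lower number here means a stronger inhibitor, a higher number a weaker inhibitor. Compound 1 `C[C@]1(O)C[C@](c2ccc(OC(F)(F)F)cc2)([C@H](O)c2ccccn2)C1` gives 1510 nM, the highest of the two numbers and therefore the weaker inhibitor. Compound 2 `C[C@]1(O)C[C@@](c2cccc(C(F)(F)F)c2)([C@H](O)c2ccccn2)C1` gives 300 nM, a lower number beyond the usual scatter, so compound 2 is the stronger inhibitor of the pair. The remaining compound, compound 3 `C[C@]1(O)C[C@@](c2ccc(OC(F)(F)F)cc2)([C@H](O)c2ccccn2)C1`, has not yet been measured in this assay.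

Compound 3 is built from exactly the same atoms and bonds as compound 1: the two compounds have the same atoms and bonds and differ only in configuration as drawn: 2 of 3 stereo elements differ; a stereocentre at a saturated ring carbon is drawn S in compound 1 and R in compound 3; a stereocentre at a saturated ring carbon is drawn r in compound 1 and s in compound 3. In plain terms, nothing is added or removed; the shared core is simply folded the other way at two of its three stereo elements, so compound 3 is a diastereomer of compound 1.

Going by the values given here, no measured pair in this set isolates such a change, so its size is an open question. A moderate move toward a lower number is expected, since compound 2 reaches 300 nM and compound 1 stands at 1510 nM. The expected step is a 3.0-fold lower number from compound 1 to compound 3 (0.48 log units; beyond the scatter). Compound 3 is therefore estimated to give 500 nM in this assay, within a range from 150 nM to 1600 nM.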

Compound 3, antagonist equilibrium constant: 330 nM
Estimate against measurement, compound 3: 1.5-fold (0.18 log units) above; measured number inside the range.
By their numbers in this assay, from the lowest: compounds 2 and 3 (each within the scatter of the next); then compound 1.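

In this assay, configuration alone moves the result: with nothing added or removed, the change gives a 4.6-fold lower number from compound 1 to compound 3 (0.66 log units; beyond the scatter). This step, which lies beyond the scatter, can be tied to the arrangement of the shared core in space, and to nothing else, because of a single fact about the pair: the fact that compounds 1 and 3 differ only in the configuration as drawn. The result also changes how the earlier numbers read: compound 3 gives 330 nM and compound 2 gives 300 nM, two values within the scatter of each other from compounds that share the same drawn configuration. Compound 1 and compound 3 both carry a trifluoromethoxy group. The data do not tie the high number of compound 1 to that group alone.

From the compounds shown here alone, both ring stereo elements change together in this pair, so it remains open whether one of them alone accounts for the step, and what inverting the third stereo element would do. Also open, going by these compounds, is how this configuration would respond if an amine or a carboxylic acid took the place of either hydroxyl group on the shared core.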